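A few compounds are considered here, and "the series" means these few. Any claim that something is new, unique, unknown or untested is made for them only; others in the source may bear on it.

- compound 1 `CCN(CC)CCNC(=O)c1ccc(C(CC)(CC)c2ccc(OCC(=O)C(C)(C)C)c(C)c2)n1CC` gives 2500 nM
- compound 2 `CCn1c(C(=O)NCCN(C)C)ccc1C(CC)(CC)c1ccc(OCC(=O)C(C)(C)C)c(C)c1` gives 2500 nM
- compound 3 `CCn1c(C(=O)NCCN)ccc1C(CC)(CC)c1ccc(OCC(=O)C(C)(C)C)c(C)c1` gives 2500 nM

All three values come from an ADME assay on L02 cells (Homo sapiens) for cytotoxicity, read by MTT assay, with a stated time of 48 h; on this read-out lower numbers stand for stronger inhibition and higher numbers for weaker inhibition. Compound 1 and compound 2 match the number of compound 3, 2500 nM, so compound 3 stands level with both.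

The next compound is compound 4 `CCn1c(C(=O)N(C)CC(=O)O)ccc1C(CC)(CC)c1ccc(OCC(=O)C(C)(C)C)c(C)c1`. Its change is (carboxymethyl)(methyl)amino in place of (2-aminoethyl)amino on a carbonyl carbon.

Three measured steps offer some guidance: no change at the digits printed from compound 1 to compound 2 (within the scatter), no change at the digits printed from compound 1 to compound 3 (within the scatter) and no change at the digits printed from compound 2 to compound 3 (within the scatter). Each swaps only the amino group at the end of the chain, and none moves the number. None of them replaces that amino group with a carboxymethyl group, however, so they are only a loose guide, and a surprise in either direction remains possible. The flat result therefore suggests no clear shift in this assay, with only a slight lean toward weaker inhibition allowed for.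

The estimated step is a 1.4-fold higher number from compound 3 to compound 4 (0.15 log units; within the scatter), so no change beyond the scatter is expected. Compound 4 is expected at about 3500 nM, with an estimated range of 1500 nM to 12000 nM.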

Compound 4, half-maximal inhibitory concentration: 8700 nM
For compound 4 the middle estimate is 2.5-fold (0.40 log units) below the measured one, and the stated range covers the measured number.
By their numbers in this assay, from the lowest: compounds 1, 2 and 3 (each within the scatter of the next); then compound 4.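

Among these compounds, putting (carboxymethyl)(methyl)amino on the carbonyl carbon is the first change here to move the number in this assay, giving a 3.5-fold higher number from compound 3 to compound 4 (0.54 log units; beyond the scatter) and a 3.5-fold higher number from compound 2 to compound 4 (0.54 log units; beyond the scatter) and also a 3.5-fold higher number from compound 1 to compound 4 (0.54 log units; beyond the scatter) in the same direction. Swapping the amino group on the chain had changed nothing, so this position does respond to a larger replacement, though only modestly and toward weaker inhibition. Nothing measured here accounts for the shift.

The carboxylic acid and the methyl on the amide nitrogen arrive together in compound 4, so the compounds shown leave open which of them goes with the higher number. A (carboxymethyl)amino group that keeps the amide hydrogen would separate the two, and a longer chain ending in a carboxylic acid would show whether chain length matters.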